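A few compounds are considered here, and "the series" means these few. Any claim that something is new, unique, unknown or untested is made for them only; others in the source may bear on it.

Of the compounds shown here, three have so far been measured in a functional assay (spleen, spleen) for activation, with Mus musculus as the target; on this read-out lower numbers stand for an effect already at smaller amounts and higher numbers for an effect only at larger amounts of compound. Compound 1 `CCCCc1nc(N)c2nc(O)n(Cc3ccccc3)c2n1` gives 0.03 uM. Where compound 1 carries a butyl group, compound 2 `CCCCNc1nc(N)c2nc(O)n(Cc3ccccc3)c2n1` carries a butylamino group, and in this assay compound 2 gives 1 uM; the step of a 33-fold higher number from compound 1 to compound 2 (1.52 log units; beyond the scatter). Compound 3 `CSc1nc2c(N)ncnc2n1Cc1ccccc1` is built on a different core, and in this assay compound 3 reaches only the limit > 10 uM. Among the two numbers, compound 2 stands highest, and its nearest neighbour is compound 1 with a markedly lower number.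

Compound 4 `CCc1nc(N)c2nc(O)n(Cc3ccccc3)c2n1` has not yet been measured. It differs from compound 2 in one place: ethyl in place of butylamino on an aromatic carbon. For the measured compounds named here, the only measured step that bears on this change is the one from compound 1 to compound 2, where butyl was exchanged for butylamino and the number rose sharply. Going by the values given here, the change to compound 4 runs the other way, back to a plain alkyl chain, though a shorter one, and no measured pair shows what a shorter chain does on its own. A large step to a lower number is therefore expected, a 10-fold lower number from compound 2 to compound 4 (1.00 log units; beyond the scatter). Compound 4 is estimated at 0.1 uM, with a range from 0.03 uM to 0.5 uM.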

Compound 4, minimum effective concentration: 1 uM
Beside the measured number, compound 4's estimate is 10-fold (1.00 log units) below it; the measured number lies above the stated range.
By their numbers in this assay, from the lowest: compound 1; then compounds 2 and 4 (each within the scatter of the next). At a limit, above all of these: compound 3.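

The position between two ring nitrogen atoms responds to the length of a plain alkyl chain, and not only to the nitrogen that links butylamino to the ring: in this assay, shortening butyl to ethyl gives a 33-fold higher number from compound 1 to compound 4 (1.52 log units; beyond the scatter). Ethyl and butylamino differ in heavy atoms and in hydrogen-bond donors and acceptors, yet exchanging one for the other gives no change at the digits printed from compound 2 to compound 4 (within the scatter). The earlier step from butyl to butylamino therefore no longer stands alone as a sign that the nitrogen matters, since a shorter chain without any nitrogen gives the same number, and among the three compounds that share this core, only the butyl of compound 1 stands apart.

A propyl or a pentyl chain at this position would show whether the number changes gradually or abruptly with chain length, and an ethylamino group would show what the nitrogen does when the chain length stays that of ethyl. Nothing given here accounts for why butyl differs so sharply from both other groups.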